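A few compounds are considered here, and "the series" means these few. Any claim that something is new, unique, unknown or untested is made for them only; others in the source may bear on it.

Measured compounds:
compound 1 `COc1cc(C)cc(-c2nn(CC#N)cc2-c2ccc(-c3cccc(C(C)=O)c3)nc2)c1` — 3450 nM
compound 2 `Cc1cc(O)cc(-c2nn(CC#N)cc2-c2ccnc(-c3ccc(Oc4ccccc4)cc3)c2)c1` — 1940 nM

Two compounds of the series have been run in a functional assay on NCI-H23 cells (Homo sapiens) for inhibition, read by sulforhodamine B assay, with a stated time of 48 h; on this read-out higher numbers stand for weaker inhibition of growth and lower numbers for stronger inhibition of growth. Compound 1 gives 3450 nM and compound 2 gives 1940 nM. The two numbers lie within the usual scatter of each other, so neither compound can be set apart from the other on this assay.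

Compound 3, `Cc1cc(O)cc(-c2nn(CC#N)cc2-c2ccnc(-c3ccc(N(C)C)cc3)c2)c1`, has not been measured. Its difference from compound 2 is dimethylamino in place of phenoxy on an aromatic carbon. Within the data shown here, no pair of measured compounds shares this change, so the two numbers in hand show nothing about how it acts on this assay. With no such comparison, a step no larger than the scatter, in either direction, is the plain expectation.

Compound 3 is therefore estimated at 2000 nM in this assay, with a range from 700 nM to 6000 nM. This estimate for compound 3 means an expected step of a 1.0-fold higher number from compound 2 to compound 3 (0.01 log units; within the scatter) that stays within the scatter.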

Compound 3, concentration for 50% growth inhibition: 4480 nM
Beside the measured number, compound 3's estimate is 2.2-fold (0.35 log units) below it; the measured number falls inside the stated range.
By their numbers in this assay, from the lowest: compounds 2, 1 and 3 (each within the scatter of the next, the first and the last beyond it).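

In this assay, among these compounds, dimethylamino in place of phenoxy, on an aromatic carbon para to a large group, gives a 2.3-fold higher number from compound 2 to compound 3 (0.36 log units; beyond the scatter), the first step that can be read between compounds differing in one place. The group held at this position therefore bears on the number, and here the smaller, ring-free dimethylamino goes with weaker inhibition of growth, though the step is modest and rests on a single pair. No available evidence bears on what lies behind this step.

The compounds shown leave open whether the aromatic ring of phenoxy or the atom joining the group to the core tracks with the number. A phenylamino group would keep the ring with a nitrogen link, and an ethoxy group would keep the oxygen without the ring.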